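Dimethylcarbamoyl for dimethylsulfamoyl: a cytotoxicity step still unmeasured

The source may hold more compounds than are shown below. What is called first, only, known or untested is meant among the compounds shown, and "the series" means these compounds.

Compound 1 (`NC(=O)c1ccc(-c2ccc(Cl)cc2COc2ccc(-c3nc4cc(C(=O)O)ccc4n3C3CCCCC3)cc2)cc1`) gives > 50000 nM as a limit
Compound 2 (`CN(C)S(=O)(=O)c1ccc(-c2ccc(Cl)cc2)c(COc2ccc(-c3nc4cc(C(=O)O)ccc4n3C3CCCCC3)cc2)c1`) gives 26000 nM as a number

Both results come from a functional assay on Huh-5-2 cells (Homo sapiens), read by MTT assay (a lower number here means that less compound is tolerated, a higher number that more compound is tolerated), and are the only ones available so far. Compound 1 is reported as > 50000 nM, which is a limit and not a number. Within the data shown here, that leaves compound 2, at 26000 nM, as the only true number in the set, so it cannot yet be ranked against anything exact.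

Compound 3 (`CN(C)C(=O)c1ccc(-c2ccc(Cl)cc2)c(COc2ccc(-c3nc4cc(C(=O)O)ccc4n3C3CCCCC3)cc2)c1`) keeps everything in compound 2 except one group: dimethylcarbamoyl in place of dimethylsulfamoyl on an aromatic carbon, para to a 4-chlorophenyl group (dimethylcarbamoyl in place of dimethylsulfamoyl on an aromatic carbon). Among the measured compounds shown here, no measured pair differs in one place only, so the data hold no direct guide to this swap. With compound 2 at 26000 nM as the only firm starting point, a small change is expected in this assay, leaning slightly towards more compound being tolerated. The expected step of a 1.3-fold higher number from compound 2 to compound 3 (0.12 log units; within the scatter) stays within the usual scatter. For compound 3 the estimate is 34000 nM, with 15000 nM to 60000 nM as the expected range.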

Compound 3, half-maximal cytotoxic concentration: 28000 nM
Beside the measured number, compound 3's estimate is 1.2-fold (0.08 log units) above it; the measured number falls inside the stated range.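

In this assay, replacing dimethylsulfamoyl with dimethylcarbamoyl on the aromatic carbon para to a 4-chlorophenyl group gives a 1.1-fold higher number from compound 2 to compound 3 (0.03 log units; within the scatter). Among these compounds, this is the first pair in the set that differs in one place only, so it offers the first direct reading at this position: the two groups cannot be told apart here, even though the sulfur is gone, the group is one heavy atom smaller, and it has one hydrogen-bond acceptor fewer. Compound 1 holds a limit and not a number, so it adds no step to this reading: the limit of > 50000 nM in this assay, at which 1 of the 3 values shown sits.

Going by these compounds, what remains open is how far this tolerance for different groups extends, as one pair at a single position cannot establish a general pattern. A nitrile, a carboxylic acid, a basic amine or a simple methyl group at the same place might read alike or might move the number beyond the scatter, and the pair says nothing about what would happen if the same swap were made elsewhere on the shared core.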